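One ring group exchanged on compound 3

The source may report more compounds than this note shows. Statements on the series, on what has been measured and on what is new or still open speak of the compounds shown alone.

In a functional assay (aorta) with Rattus norvegicus as the target, in the presence of a further agent that is not named here (a higher number here means that more compound is needed for the effect, a lower number that less compound is needed), compound 1 (`COC(=O)C1=C(C)N=C(C)/C(=C(\O)OC)C1c1cccc([N+](=O)[O-])c1`) gives 3.4 nM and compound 2 (`COC(=O)C1=C(C)N=C(C)/C(=C(/O)OC)C1c1cccc(OCc2nonc2C)c1`) gives 640 nM, while compound 3 (`COC(=O)C1=C(C)N=C(C)/C(=C(/O)OC)C1c1ccccc1OCc1nonc1C`) gives 41 nM on the same scale. Compound 3 therefore stands in the middle, with a number clearly higher than that of compound 1 and clearly lower than that of compound 2. Compound 4 (`COC(=O)C1=C(C)N=C(C)/C(=C(/O)OC)C1c1ccccc1OCc1c(C#N)no[n+]1[O-]`) differs from compound 3 in one group, on a saturated chain carbon bound to an oxygen on an aromatic ring (a group of 8 heavy atoms (3 carbon, 3 nitrogen, 2 oxygen; one five-membered aromatic ring with 3 hetero atoms) in place of a group of 6 heavy atoms (3 carbon, 2 nitrogen, 1 oxygen; one five-membered aromatic ring with 3 hetero atoms), on a saturated chain carbon bound to an oxygen on an aromatic ring). Among the compounds with values here, no measured pair shows a change of this kind, so the size of the step remains uncertain. In this assay no step beyond the scatter is expected (a 1.4-fold lower number from compound 3 to compound 4 (0.14 log units; within the scatter) is the estimated step). The estimate for compound 4 is 30 nM within an expected range of 8 nM to 120 nM overall.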

Compound 4, half-maximal effective concentration: 9.4 nM
Beside the measured number, compound 4's estimate is 3.2-fold (0.50 log units) above it, within the range that was stated.
By their numbers in this assay, from the lowest: compound 1; then compound 4; then compound 3; then compound 2.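

In this assay, the ring group on the saturated chain carbon bound to an oxygen on an aromatic ring proves to matter: replacing 4-methyl-1,2,5-oxadiazol-3-yl with the larger ring group carrying a triple bond gives a 4.4-fold lower number from compound 3 to compound 4 (0.64 log units; beyond the scatter). Within the data shown here, the earlier compounds offered no step at this place, so this is the first sign that the number responds to a change here. Nothing shown explains the step.

As far as these compounds go, both the triple bond and the additional oxygen enter together, so their separate shares stay open. Whether a plain phenyl ring here would give a similar number is also unknown.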